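A second methyl on the core of compound 2

The source may report more compounds than this note shows. Statements on the series, on what has been measured and on what is new or still open speak of the compounds shown alone.

The shared core is seen in compound 1 `c1ccc2ncc(-c3nn[nH]n3)cc2c1`. In a functional assay on the whole organism (strain Sprague-Dawley) for inhibition, with Rattus norvegicus as the target (on this read-out higher numbers stand for an effect only at larger amounts of compound and lower numbers for an effect already at smaller amounts), compound 1 gives 10 mg/kg. Compound 2 `Cc1cccc2cc(-c3nn[nH]n3)cnc12` carries a methyl in place of hydrogen on an aromatic carbon of that core. For compound 2 this assay reports only a limit, < 25 mg/kg, and compound 2 stands on this limit alone, not on a number. Compound 3 `Fc1cccc2cc(-c3nn[nH]n3)cnc12` carries fluoro in place of hydrogen on the same core. For compound 3 this assay likewise reports only a limit, > 10 mg/kg. The measured steps are a step that the limit leaves unreadable from compound 1 to compound 2, a number no lower from compound 1 to compound 3 (the limit leaves the size open) and a step that the limit leaves unreadable from compound 2 to compound 3; each rests on one of the two limits, the limit of < 25 mg/kg in this assay, at which 1 of the 3 values shown sits, and (the limit of > 10 mg/kg in this assay, at which 1 of the 3 values shown sits), so none of them has a readable size.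

Compound 4 `Cc1ccc2cc(-c3nn[nH]n3)cnc2c1C` differs from compound 2 by methyl in place of hydrogen on an aromatic carbon. Among the compounds with values here, no measured step with a readable size bears on this change, so for compound 4 no step beyond the scatter in this assay is expected, a step that the limit leaves unreadable from compound 2 to compound 4. Compound 4 is therefore estimated at 10 mg/kg, with a range from 3 mg/kg to 30 mg/kg, and the assay may again report only a limit.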

Compound 4, minimum effective dose: 1 mg/kg
The estimate for compound 4 lay 10-fold (1.00 log units) above the measured number; measured number outside the range, below it.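

In this assay compound 4 gives a number, yet no step from compound 2 to compound 4 can be read, because compound 2 stands on a limit and not on a number: the limit of < 25 mg/kg in this assay, at which 1 of the 4 values shown sits.

The compounds shown leave open how much the added methyl changes the minimum effective dose of compound 2, and whether compound 2 differs from compound 1 at all.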